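Adding Fluoro to the Phenyl of Compound 2

A few compounds are considered here, and "the series" means these few. Any claim that something is new, unique, unknown or untested is made for them only; others in the source may bear on it.

In a functional assay on HeLa cells (Homo sapiens) for inhibition, with a stated time of 72 h (on this read-out lower numbers stand for stronger inhibition and higher numbers for weaker inhibition), compound 1 `NC1CCC(Nc2nc(NCc3ccc(Br)cc3)c3ncn(C4CCCC4)c3n2)CC1` gives 1510 nM and compound 2 `NC1CCC(Nc2nc(NCc3ccc(-c4ccccc4)nc3)c3ncn(C4CCCC4)c3n2)CC1` gives 114 nM as the lower of the two numbers. Within the data shown here, the one measured step of a 13-fold lower number from compound 1 to compound 2 (1.12 log units; beyond the scatter) came with 6-phenylpyridin-3-yl in place of 4-bromophenyl. Compound 3 `NC1CCC(Nc2nc(NCc3ccc(-c4cccc(F)c4)nc3)c3ncn(C4CCCC4)c3n2)CC1` differs from compound 2 through fluoro in place of hydrogen on an aromatic carbon in the form of fluoro in place of hydrogen on an aromatic carbon. Among the measured compounds shown here, that earlier step exchanged a much larger group and bears only weakly here, and no fluoro step has been measured. The expected change a 1.1-fold lower number from compound 2 to compound 3 (0.06 log units; within the scatter) is therefore small and within the scatter. Compound 3 is estimated at 100 nM with a range from 45 nM to 220 nM expected.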

Compound 3, half-maximal inhibitory concentration: 36 nM
For compound 3 the middle estimate is 2.8-fold (0.44 log units) above the measured one, and the stated range ends above it.
By their numbers in this assay, from the lowest: compound 3; then compound 2; then compound 1.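

In this assay, fluoro in place of hydrogen on the phenyl ring, meta to a large group, brings a 3.2-fold lower number from compound 2 to compound 3 (0.50 log units; beyond the scatter) and so shows that this ring position responds to a change of a single atom. The earlier step exchanged a much larger group and could not show this. Nothing available here explains the size of this step. On these data alone, whether chloro, methoxy or an amine at the same position would give a similar number remains open, as does the effect of fluoro elsewhere on this phenyl ring.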